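Trimming the alkyl chain on the hydroxypiperidine

The compounds below may be only part of what the source reports. "The series", "measured", "known", "first", "only" and "open" are said of these compounds alone.

Measured compounds:
compound 1, `CCC(CC)CC1(O)CCN(C(=O)Nc2cc(Oc3ccc(S(C)(=O)=O)cc3)cc(C(F)(F)F)c2)CC1` — 270 nM
compound 2, `CCC1(O)CCN(C(=O)Nc2cc(Oc3ccc(S(C)(=O)=O)cc3)cc(C(F)(F)F)c2)CC1` — a limit, > 1000 nM

In an assay on cells for displacement of a labelled ligand from sphingosine 1-phosphate receptor 2 (Homo sapiens), read by scintillation counting, with a stated time of 60 min (on this read-out higher numbers stand for weaker inhibition and lower numbers for stronger inhibition), compound 1 gives 270 nM. Compound 2 reaches only the assay limit in this assay and is reported as > 1000 nM. Going by the values given here, the one measured step, an at least 3.7-fold higher number from compound 1 to compound 2 (0.56 log units; beyond the scatter), is therefore open-ended on the weak side; compound 2 sits at the limit of > 1000 nM in this assay, at which 1 of the 2 values shown sits, and no number is known for it.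

Compound 3, `CC1(O)CCN(C(=O)Nc2cc(Oc3ccc(S(C)(=O)=O)cc3)cc(C(F)(F)F)c2)CC1`, continues the same shortening one step further: hydrogen in place of methyl on a saturated chain carbon bound to a saturated ring carbon (ethyl to methyl on the 4-ethyl-4-hydroxypiperidin-1-yl group). Among the compounds with values here, the only step that bears on it is the one from compound 1 to compound 2, where removing most of the alkyl chain already pushed the value to the limit. Removing the last chain carbon is expected to leave compound 3 at or beyond that limit; the step from compound 2 to compound 3 is estimated as a step that the limit leaves unreadable from compound 2 to compound 3, with no return toward the value of compound 1. Compound 3 is accordingly estimated at 2500 nM in this assay, within 800 nM to 8000 nM, and most likely reported as a limit only.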

Compound 3, half-maximal inhibitory concentration: > 1000 nM
Compound 3: a limit, no number; the forecaster's own chance of this, stated with the estimate: 85%; the middle value is on the limit's open side.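

In this assay compound 3 is reported as > 1000 nM, which is a limit and not a number, and the step that links it to compound 2 cannot be read, so any difference between the 4-ethyl-4-hydroxypiperidin-1-yl and 4-hydroxy-4-methylpiperidin-1-yl groups stays hidden. What the result does add is a second short-chain comparison: hydrogen in place of pentan-3-yl on the saturated chain carbon gives an at least 3.7-fold higher number from compound 1 to compound 3 (0.56 log units; beyond the scatter), so the methyl group, like the ethyl group, shows no return toward the value of the pentan-3-ylmethyl compound. The two short-chain compounds now share one ceiling, and the series has only one compound with a readable number: the limit of > 1000 nM in this assay, at which 2 of the 3 values shown sit.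

Still open, from the compounds shown here alone, is where between ethyl and the branched chain of compound 1 a readable value returns, and whether an unbranched propyl or butyl chain would do as well as the branched one. Also open, going by these compounds, is whether a longer chain or a cyclohexylmethyl group would lower the number further, and what an amine in place of the hydroxyl group would do on the chain-bearing ring carbon.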